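Methoxy addition to compound 2: working notes

The compounds below may be only part of what the source reports. "The series", "measured", "known", "first", "only" and "open" are said of these compounds alone.

Values so far in a functional assay on HeLa cells (Homo sapiens) for cytotoxicity, read by MTT assay, with a stated time of 24 h; a higher number here means a weaker inhibitor, a lower number a stronger inhibitor:
compound 1 `COc1cc(/C=C2\CN(C)C/C(=C\c3ccccc3F)C2=O)cc(OC)c1` gives 5450 nM
compound 2 `COc1cc(/C=C2\CN(C)C/C(=C\c3ccc(F)cc3)C2=O)cc(OC)c1` gives 10200 nM
compound 3 `COc1cc(/C=C2\CN(C)C/C(=C\c3ccc(Cl)cc3)C2=O)cc(OC)c1` gives 11200 nM

Among the compounds with values here, compound 2 stands close to both other compounds: the data show a 1.9-fold higher number from compound 1 to compound 2 (0.27 log units; within the scatter) and also a 1.1-fold higher number from compound 2 to compound 3 (0.04 log units; within the scatter) while the one step past the scatter is a 2.1-fold higher number from compound 1 to compound 3 (0.31 log units; beyond the scatter) and it remains modest.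

Compound 4 `COc1cc(/C=C2\CN(C)C/C(=C\c3ccc(F)cc3)C2=O)cc(OC)c1OC` changes compound 2 as follows: methoxy in place of hydrogen on an aromatic carbon with methoxy in place of hydrogen on an aromatic carbon, ortho to two methoxy groups and para to a large group. Within the data shown here, none of the measured steps touches this carbon. Among the measured compounds shown here, all three alter only the halogen-bearing phenyl group, so they offer a scale for this assay but no direct precedent. For the measured compounds named here, with steps of that size as the only guide, no step beyond the scatter is expected. The estimated step is a 1.3-fold lower number from compound 2 to compound 4 (0.11 log units; within the scatter) and its direction remains uncertain. Compound 4 is estimated at 8000 nM with an expected range from 3000 nM to 20000 nM as a working figure.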

Compound 4, half-maximal inhibitory concentration: 7250 nM
Estimate against measurement, compound 4: 1.1-fold (0.04 log units) above; the range from low to high includes it.
By their numbers in this assay, from the lowest: compounds 1, 4, 2 and 3 (each within the scatter of the next, the first and the last beyond it).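

In this assay, within the data shown here, methoxy in place of hydrogen on the aromatic carbon ortho to two methoxy groups and para to a large group gives a 1.4-fold lower number from compound 2 to compound 4 (0.15 log units; within the scatter), the first reading for a change away from the halogen-bearing phenyl group. This one pair therefore shows that the added methoxy at this carbon leaves the number within the scatter of compound 2, with the 4-fluorophenyl group held constant. No supporting measurement bears on the reason for this result.

Going by these compounds, whether a hydroxyl, an amine or a longer chain such as ethoxy at this carbon would give a step beyond the scatter remains open. Also open, on these data alone, is whether the same methoxy addition would give a comparable step alongside the 2-fluorophenyl or 4-chlorophenyl group.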